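Swapping a chain amine for a hydroxypiperidine ring

The source may report more compounds than this note shows. Statements on the series, on what has been measured and on what is new or still open speak of the compounds shown alone.

Measured so far, in an assay on isolated protein (Cavia porcellus) with Sigma non-opioid intracellular receptor 1 (Homo sapiens) as the target, read by radioligand binding; a lower number here means a stronger inhibitor, a higher number a weaker inhibitor:
Compound 1 `O=c1cc(-c2ccccc2)oc2cccc(OCCCN3CCC(O)CC3)c12` gives 125 nM.
Compound 2 `O=c1cc(-c2ccccc2)oc2cccc(OCCCCN3CCC(O)CC3)c12` gives 58 nM.
Compound 3 `CN(C)CCCCCCCOc1ccc2oc(-c3ccccc3)cc(=O)c2c1` gives 165 nM.

Compound 3 has the highest number of the three, so it is the weakest inhibitor shown, though its gap to compound 1 lies within the scatter. Compound 4 `O=c1cc(-c2ccccc2)oc2ccc(OCCCN3CCC(O)CC3)cc12` differs from compound 3 by 4-hydroxypiperidin-1-yl in place of 4-(dimethylamino)butyl on a saturated chain carbon, three bonds along the chain from an oxygen on an aromatic ring. Going by the values given here, the only measured step, a 2.2-fold lower number from compound 1 to compound 2 (0.33 log units; beyond the scatter), concerns chain length and does not bear on this swap. Compound 1 and compound 4 share the same chain and ring amine but differ in where the chain attaches to the core; their values alone can guide the guess. A step of a 1.4-fold lower number from compound 3 to compound 4 (0.14 log units; within the scatter) is therefore expected, leaving compound 4 near compound 1, with an estimate of 120 nM (range 40 nM to 400 nM).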

Compound 4, half-maximal inhibitory concentration: 130 nM
For compound 4 the middle estimate is 1.1-fold (0.03 log units) below the measured one, within the range that was stated.
By their numbers in this assay, from the lowest: compound 2; then compounds 1, 4 and 3 (each within the scatter of the next).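

In this assay, 4-hydroxypiperidin-1-yl in place of 4-(dimethylamino)butyl gives a 1.3-fold lower number from compound 3 to compound 4 (0.10 log units; within the scatter), so a ring and a hydrogen-bond donor can enter on this saturated chain carbon without a shift beyond the scatter. Nothing shown explains why these two groups read so alike.

Still open, on these data alone, is whether the hydroxyl matters at all, which piperidin-1-yl without it or a morpholine ring at this place could test. Also open, as far as these compounds go, is whether the longer chain of compound 2 would lower the number on the core of compound 4.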